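The source may hold more compounds than are shown below. What is called first, only, known or untested is meant among the compounds shown, and "the series" means these compounds.

Measured in an ADME assay on TZM cells (Homo sapiens) for cytotoxicity, read by CCK-8 assay, with a stated time of 2 days; on this read-out lower numbers stand for higher toxicity in this test and higher numbers for lower toxicity in this test:
compound 1 `CC(=O)Oc1ccc(/C=C/S(=O)(=O)CCc2ccc(NC(=O)c3cc(F)cc(F)c3)cc2)cc1OC(C)=O`: 225000 nM
compound 2 `COc1ccc(C(=O)Nc2ccc(CCS(=O)(=O)/C=C/c3ccc(O)c(O)c3)cc2)cc1`: > 1000000 nM (a limit of the assay, not a number)

Among the compounds with values here, compound 2 stands at the limit, and the series so far shows (the limit of > 1000000 nM in this assay, at which 1 of the 2 values shown sits). Only compound 1 therefore carries a true number.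

Compound 3 `O=C(Nc1ccc(CCS(=O)(=O)/C=C/c2ccc(O)c(O)c2)cc1)C1CCCCC1` departs from compound 2 by a single change: cyclohexyl in place of 4-methoxyphenyl on a carbonyl carbon. This places cyclohexyl in place of 4-methoxyphenyl on a carbonyl carbon.

Within the data shown here, no measured pair shows this change, so the expectation is loose. Compound 3 may again read only as a limit of the assay. If it gives a number, a modest move toward lower numbers in this assay is expected, with compound 1 at 225000 nM as the only numerical reference. The expected step is an at least 1.6-fold lower number from compound 2 to compound 3 (0.22 log units; that floor lies within the scatter). For compound 3 the estimated value is 600000 nM, within an expected range of 200000 nM to 1000000 nM.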

Compound 3, half-maximal cytotoxic concentration: 638000 nM
The estimate for compound 3 lay 1.1-fold (0.03 log units) below the measured number, within the range that was stated.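

Cyclohexyl in place of 4-methoxyphenyl on a carbonyl carbon gives, in this assay, an at least 1.5-fold lower number from compound 2 to compound 3 (0.19 log units; that floor lies within the scatter). Compound 3 thus provides a true number at this position, where compound 2 provides none. Compound 2 stands at a limit of the assay, not at a number, so the step has only a floor and its full size cannot be read: the limit of > 1000000 nM in this assay, at which 1 of the 3 values shown sits.

The change removes the methoxy group and the aromatic ring together, and these compounds do not separate the two; an unsubstituted phenyl or a straight butyl chain on the same carbonyl carbon would bear on that. On these data alone, compound 1 differs from compound 3 in more than one place, so how the groups on the shared core contribute remains open.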